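The source may report more compounds than this note shows. Statements on the series, on what has been measured and on what is new or still open speak of the compounds shown alone.

In a functional assay on K562 cells (Homo sapiens) for antiproliferative activity, read by resazurin assay, with a stated time of 72 h (on this read-out higher numbers stand for weaker inhibition and lower numbers for stronger inhibition), two compounds have been measured: compound 1 `N#Cc1c(-c2ccc(F)cc2)nc2c(c(-c3ccccc3)nn2-c2ccccc2)c1-c1ccc(O)cc1` gives 10200 nM and compound 2 `COc1cc(-c2c(C#N)c(-c3ccco3)nc3c2c(-c2ccccc2)nn3-c2ccccc2)ccc1O` gives 24900 nM.

Of these two numbers, compound 1 has the lower one, and the gap to compound 2 lies beyond the usual scatter of repeated measurements. Compound 3 `N#Cc1c(-c2ccccc2)nc2c(c(-c3ccccc3)nn2-c2ccccc2)c1-c1ccc(O)cc1` has not yet been measured in this assay. It differs from compound 1 by hydrogen in place of fluoro on an aromatic carbon. Within the data shown here, no measured pair here shows a change of this kind, so the expectation rests on the change being small: the step of a 1.2-fold higher number from compound 1 to compound 3 (0.07 log units; within the scatter) is expected to stay within the scatter, with no clear direction. Compound 3 is therefore estimated at 12000 nM, with a likely range from 5000 nM to 30000 nM.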

Compound 3, half-maximal inhibitory concentration: 9600 nM
The estimate for compound 3 lay 1.3-fold (0.10 log units) above the measured number; low and high end bracket the measured number.
By their numbers in this assay, from the lowest: compounds 3 and 1 (each within the scatter of the next); then compound 2.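

In this assay going from 4-fluorophenyl to phenyl gives a 1.1-fold lower number from compound 1 to compound 3 (0.03 log units; within the scatter) and so no difference that stands out from the scatter. Among these compounds, this is the first direct comparison, and it shows that fluoro and hydrogen read alike at this position on the core of compound 1. Nothing available explains this result. On these data alone, whether an amine, a carboxylic acid or a longer chain on this same carbon would also read alike remains open. A swap this small cannot show how much this position matters.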